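Removing a Methyl Beside the Hydroxy Group: Compound 4

This account rests on a few compounds, and the source may have more. Where it says the series, first, only, none or still open, it means among the compounds named here.

Measured so far in an ADME assay on Raji cells (Homo sapiens) for cytotoxicity, with a stated time of 72 h; a lower number here means that less compound is needed, a higher number that more compound is needed for the effect:
Compound 1, `Cc1cc(NC(=O)c2cc([N+](=O)[O-])ccc2Cl)cc(-c2nc3ccccc3s2)c1O`: > 25000 nM, a limit of the assay rather than a number.
Compound 2, `O=C(Nc1cc(-c2nc3ccccc3s2)ccc1Cl)c1cc([N+](=O)[O-])ccc1Cl`: > 25000 nM, likewise a limit.
Compound 3, `O=C(Nc1nc(-c2ccc(Cl)cc2)cs1)c1cc([N+](=O)[O-])ccc1Cl`: 12000 nM.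

Compound 1 thus stands at the limit of > 25000 nM in this assay, at which 2 of the 3 values shown sit, so no number is known for it. Going by the values given here, no single-change step between measured compounds exists, so nothing indicates how a small change shifts this read-out. Compound 4, `O=C(Nc1ccc(O)c(-c2nc3ccccc3s2)c1)c1cc([N+](=O)[O-])ccc1Cl`, differs from compound 1 in one place: hydrogen in place of methyl on an aromatic carbon. Methyl leaves and hydrogen enters on an aromatic carbon of a six-membered aromatic ring of carbon only, ortho to a hydroxy group. In this assay no step beyond the scatter is expected. Compound 4 is estimated at 30000 nM, between 10000 nM and 100000 nM. The expected step that the limit leaves unreadable from compound 1 to compound 4 is essentially none.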

Compound 4, half-maximal effective concentration: > 25000 nM
Compound 4: only a limit was reported; the forecaster's own chance of this, stated with the estimate: 70%; the middle value lies beyond the limit too.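

In this assay, going by these compounds alone, compound 1 and compound 4 both give only a limit, so no step between them can be read. From the compounds shown here alone, how far hydrogen in place of methyl shifts the read-out, if at all, stays open.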